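A Methoxy Group Added to an Already Extended Amide

The source may hold more compounds than are shown below. What is called first, only, known or untested is meant among the compounds shown, and "the series" means these compounds.

Of the compounds shown here, two have so far been tested in a functional assay (Pituitary gland cell) with Rattus norvegicus as the target; a higher number here means that more compound is needed for the effect, a lower number that less compound is needed. Compound 1 `CC(C)(N)CC(=O)N[C@@H]1CCc2ccccc2N(Cc2ccc(-c3ccccc3C(N)=O)cc2)C1=O` carries a plain amide and gives 0.08 uM. Going by the values given here, compound 2 `CC(C)(N)CC(=O)N[C@@H]1CCc2ccccc2N(Cc2ccc(-c3ccccc3C(=O)NCc3ccccc3)cc2)C1=O` adds a benzyl group to that amide nitrogen; in this assay compound 2 gives 0.9 uM, the higher of the two numbers, and the only measured step, an 11-fold higher number from compound 1 to compound 2 (1.05 log units; beyond the scatter), shows that considerably more compound was needed after that extension. Compound 3 `COc1ccc(CNC(=O)c2ccccc2-c2ccc(CN3C(=O)[C@H](NC(=O)CC(C)(C)N)CCc4ccccc43)cc2)cc1` builds on the same benzyl group: methoxy in place of hydrogen on an aromatic carbon, so that benzyl becomes 4-methoxybenzyl. Among the compounds with values here, no measured pair shows what a methoxy group does on the shared core; the one measured step concerns a much larger addition at the amide nitrogen and does not transfer directly. With only that to go on, the expectation is a small shift, if any beyond the scatter, the estimated step being a 1.7-fold higher number from compound 2 to compound 3 (0.22 log units; within the scatter). Compound 3 is therefore expected to give about 1.5 uM in this assay, with a likely range from 0.5 uM to 5 uM.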

Compound 3, concentration for half-maximal effect: 2 uM
Beside the measured number, compound 3's estimate is 1.3-fold (0.12 log units) below it; the measured number falls inside the stated range.
By their numbers in this assay, from the lowest: compound 1; then compound 2; then compound 3.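

In this assay, methoxy in place of hydrogen on an aromatic carbon brings a 2.2-fold higher number from compound 2 to compound 3 (0.35 log units; beyond the scatter), so the far end of the extended amide still responds to a change of only two heavy atoms. Measured from the plain amide, the full 4-methoxybenzyl group gives a 25-fold higher number from compound 1 to compound 3 (1.40 log units; beyond the scatter), a larger rise than benzyl alone gives with an 11-fold higher number from compound 1 to compound 2 (1.05 log units; beyond the scatter), so here the methoxy group adds to the rise that came with the extension and recovers none of it. No supporting measurement accompanies these numbers, and the reason for the shift remains unknown.

The compounds shown cannot tell whether this rise is particular to methoxy or would follow any group at that same carbon, a question that fluorine, a hydroxyl group or a carboxylic acid there could help to settle. They also leave open how much of the larger rise from the plain amide already appears with a group as small as methyl on the amide nitrogen.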